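From 4-Nitrobenzyl to 3-Phenylprop-2-en-1-yl in Mice

The source may report more compounds than this note shows. Statements on the series, on what has been measured and on what is new or still open speak of the compounds shown alone.

Of the compounds shown here, three have so far been tested in a functional assay with Mus musculus as the target; on this read-out lower numbers stand for an effect already at smaller amounts and higher numbers for an effect only at larger amounts of compound. Compound 1 `C=CCn1c(=S)n([C@@H]2O[C@H](CO)[C@H]3OC(C)(C)O[C@H]32)c2nc(N)nc(O)c21` gives 45 uM, compound 2 `Nc1nc(O)c2c(n1)n(C1OC(CO)[C@@H](O)[C@H]1O)c(=O)n2Cc1ccc([N+](=O)[O-])cc1` gives 50 uM, and compound 3 `C=CCn1c(=S)n(C2OC(COC(C)=O)[C@H]3OC(C)(C)O[C@@H]23)c2nc(N)nc(O)c21` gives 50 uM. Compound 2 and compound 3 show the same number at the digits given, and the number for compound 1 differs from that of compound 2 by less than the usual scatter, so compound 2 stands level with the other two rather than above or below them.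

Compound 4 `Nc1nc(O)c2c(n1)n(C1OC(CO)[C@@H](O)[C@H]1O)c(=O)n2C/C=C/c1ccccc1` has not yet been measured. It differs from compound 2 in one place: 2-phenylethenyl in place of 4-nitrophenyl on a saturated chain carbon bound to an aromatic nitrogen. The rest of compound 2 is kept unchanged. For the measured compounds named here, no pair of measured compounds differs in a single place, so no measured step can guide the expectation. Since the three measured numbers sit close together despite quite different side groups, the step expected in this assay is no change at the digits printed from compound 2 to compound 4 (within the scatter), in no direction beyond the scatter. Compound 4 is therefore estimated at 50 uM, with a likely range from 20 uM to 120 uM.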

Compound 4, concentration for half-maximal effect: 4 uM
Compound 4: middle estimate off by 13-fold (1.10 log units), on the high side; the whole stated range lies above it.
By their numbers in this assay, from the lowest: compound 4; then compounds 1, 2 and 3 (each within the scatter of the next).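

In this assay, for the compounds shown here, the change from 4-nitrobenzyl to 3-phenylprop-2-en-1-yl gives a 13-fold lower number from compound 2 to compound 4 (1.10 log units; beyond the scatter) and is the first single-place change that can be read here, showing that the number responds to what this position carries. Both groups hold one six-membered aromatic ring of carbon only and one double bond outside aromatic rings, so these shared features alone do not set the lower number. No measurement at hand explains what in the change produces this step.

Still open, as far as these compounds go, is whether the step goes with removing the nitro group from the ring or with the double bond in the chain, a question that plain benzyl and 3-phenylpropyl at this place could help separate. Also open, from the compounds shown here alone, is how an amine or a carboxylic acid on the phenyl ring would fare.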